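Swapping a Fluorophenyl Arm for a Vinyl Group

The source may hold more compounds than are shown below. What is called first, only, known or untested is meant among the compounds shown, and "the series" means these compounds.

Measured compounds:
compound 1, `Cc1nc(C#Cc2cccc(O)c2)cs1`: 654 nM
compound 2, `COC(=O)Nc1nc(C#Cc2cccnc2)cs1`: > 10000 nM
compound 3, `Cc1nc(C#Cc2cncc(-c3ccc(F)cc3)c2)cs1`: 162 nM

All three were tested in a functional assay on CHO cells for agonist activity at metabotropic glutamate receptor 5 (Homo sapiens), read by inositol phosphate accumulation; on this read-out higher numbers stand for weaker inhibition and lower numbers for stronger inhibition. Compound 3 gives the lowest of the two numbers in this assay; its nearest neighbour, compound 1, sits at a higher number, and that gap lies beyond the usual scatter. Compound 2 does not give a number at all but only the limit of this assay, (the limit of > 10000 nM in this assay, at which 1 of the 3 values shown sits).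

Compound 4, `C=Cc1cncc(C#Cc2csc(C)n2)c1`, has not yet been tested. It differs from compound 3 in one place: vinyl in place of 4-fluorophenyl on an aromatic carbon. Going by the values given here, no pair of measured compounds shows this kind of exchange, so no measured step can guide the expectation directly. A vinyl group is much smaller than a 4-fluorophenyl group, and the expectation is that the number rises, that is, that inhibition weakens by a moderate but real step. The expected step is a 4.9-fold higher number from compound 3 to compound 4 (0.69 log units; beyond the scatter). Compound 4 is therefore estimated at 800 nM, with a plausible range from 250 nM to 3000 nM.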

Compound 4, half-maximal inhibitory concentration: 2.01 nM
Compound 4: middle estimate off by 400-fold (2.60 log units), on the high side; the whole stated range lies above it.
By their numbers in this assay, from the lowest: compound 4; then compound 3; then compound 1. At a limit, above all of these: compound 2.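

In this assay, this position on the six-membered aromatic ring with 1 nitrogen does not depend on the large 4-fluorophenyl arm, since vinyl in its place gives an 81-fold lower number from compound 3 to compound 4 (1.91 log units; beyond the scatter). As a lower number stands for stronger inhibition, the smaller group, with no ring and only 2 heavy atoms against 7, is much the better of the two at this position. Nothing among the data given explains why this exchange strengthens inhibition so much.

Going by these compounds, it remains open whether the double bond of the vinyl group matters or only its small size, a question that an ethyl or a methyl group at this position could help to settle. On these data alone, it is also open whether an amine or a methoxy group of similar size would do as well.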